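From furan-2-yl to 1-benzofuran-2-yl on a shared core

A few compounds are considered here, and "the series" means these few. Any claim that something is new, unique, unknown or untested is made for them only; others in the source may bear on it.

Going by the values given here, in a toxicity assay on Huh-7 cells (Homo sapiens) for cytotoxicity, with a stated time of 3 days (a lower number here means that less compound is tolerated, a higher number that more compound is tolerated), compound 2 (`C[C@@]1(O)[C@H](O)[C@@H](CO)O[C@H]1n1cc(-c2ccco2)c2c(N)ncnc21`) gives 49600 nM and stands level with compound 3 (`C[C@@]1(O)[C@H](O)[C@@H](CO)O[C@H]1n1cc(-c2cccs2)c2c(N)ncnc21`) at 48100 nM among the three numbers known. The exchange between them is a 1.0-fold lower number from compound 2 to compound 3 (0.01 log units; within the scatter) and offers little guidance. Compound 1 (`C[C@@]1(O)[C@H](O)[C@@H](CO)O[C@H]1n1cc(-c2ccc3ccccc3c2)c2c(N)ncnc21`), which carries naphthalen-2-yl, gives 20100 nM and sits lower than both. In compound 4 (`C[C@@]1(O)[C@H](O)[C@@H](CO)O[C@H]1n1cc(-c2cc3ccccc3o2)c2c(N)ncnc21`), not yet measured, 1-benzofuran-2-yl takes the place of furan-2-yl on an aromatic carbon, a change counted as 1-benzofuran-2-yl in place of furan-2-yl on an aromatic carbon on the shared core. Like 1-benzofuran-2-yl, naphthalen-2-yl has two aromatic rings, so the closest evidence comes from compound 1. Its steps are a 2.5-fold higher number from compound 1 to compound 2 (0.39 log units; beyond the scatter) and a 2.4-fold higher number from compound 1 to compound 3 (0.38 log units; beyond the scatter), both modest. Read in reverse, they suggest a modest move towards a lower number, although this rests on compound 1 alone. The expected change is a 2.1-fold lower number from compound 2 to compound 4 (0.32 log units; beyond the scatter) and could still fall within the scatter. For compound 4 the estimated value is 24000 nM with an expected range of 10000 nM to 50000 nM in this assay.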

Compound 4, half-maximal cytotoxic concentration: 29400 nM
Compound 4: the middle estimate sits 1.2-fold (0.09 log units) below what was measured; the measured number falls inside the stated range.
By their numbers in this assay, from the lowest: compounds 1, 4, 3 and 2 (each within the scatter of the next, the first and the last beyond it).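

In this assay, fusing a six-membered aromatic ring of carbon only onto furan-2-yl gives a 1.7-fold lower number from compound 2 to compound 4 (0.23 log units; within the scatter) and exchanging thiophen-2-yl for 1-benzofuran-2-yl gives a 1.6-fold lower number from compound 3 to compound 4 (0.21 log units; within the scatter) so neither step separates this two-ring group from the one-ring groups at this aromatic carbon. Against the other two-ring group, naphthalen-2-yl, the change gives a 1.5-fold higher number from compound 1 to compound 4 (0.17 log units; within the scatter) so compound 4 stays within the scatter of all three earlier compounds, even though compound 1 lies beyond the scatter of both compound 2 and compound 3.

The compounds shown carry only aromatic rings on this carbon, so how an open-chain amine or a carboxylic acid would read there remains open. Nothing available explains these numbers.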